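The source may report more compounds than this note shows. Statements on the series, on what has been measured and on what is new or still open speak of the compounds shown alone.

The measured compounds so far:

Compound 1 `COc1cc2ncnc(Nc3cccc(Cl)c3F)c2cc1OCCCCC(=O)Nc1ccc(S(N)(=O)=O)cc1` gives 10500 nM in a functional assay on A549 cells (Homo sapiens) for antiproliferative activity, read by MTT assay, with a stated time of 72 h; on this read-out higher numbers stand for weaker inhibition and lower numbers for stronger inhibition.
Compound 2 `NS(=O)(=O)c1ccc(NC(=S)Nc2ccc3ncnc(Nc4ccc(F)c(Br)c4)c3c2)cc1` gives > 40000 nM in this assay, which is a limit of the measurement and not a number.
Compound 3 `NS(=O)(=O)c1ccc(NC(=S)Nc2ccc3ncnc(Nc4ccc(C(F)(F)F)cc4)c3c2)cc1` gives > 40000 nM in this assay, likewise only a limit.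

Compound 3 thus stands at the limit, the situation summed up by the limit of > 40000 nM in this assay, at which 2 of the 3 values shown sit. Because compound 2 sits at the same limit, the step that the two limits leave unreadable from compound 2 to compound 3 cannot be read in either direction. Compound 4 `CCc1ccc(Nc2ncnc3ccc(NC(=S)Nc4ccc(S(N)(=O)=O)cc4)cc23)cc1` differs from compound 3 in one place: ethyl in place of trifluoromethyl on an aromatic carbon. Among the measured compounds shown here, no measured step bears directly on this exchange, and the only step that alters the same aryl group is the unreadable one just mentioned. The evidence therefore gives no reason to expect a readable change in this assay. Compound 4 is expected to give about 40000 nM, between 15000 nM and 120000 nM, in this assay. The estimated step of a number no higher from compound 3 to compound 4 (the limit leaves the size open) amounts to nothing beyond the scatter, and the result may again be reported only as a limit.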

Compound 4, half-maximal inhibitory concentration: 24600 nM
Compound 4: the middle estimate sits 1.6-fold (0.21 log units) above what was measured; measured number inside the range.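

In this assay, among the compounds shown here, compound 4 is the only compound with this shared core that gives a number rather than a limit, so the group on this aromatic carbon can leave the measurement within reach of the assay. Ethyl in place of trifluoromethyl gives an at least 1.6-fold lower number from compound 3 to compound 4 (0.21 log units; that floor lies within the scatter), and 4-ethylphenyl in place of 3-bromo-4-fluorophenyl gives an at least 1.6-fold lower number from compound 2 to compound 4 (0.21 log units; that floor lies within the scatter). Each size is only a floor, and neither step proves a real difference, because the partner compound in each pair gives no number: the limit of > 40000 nM in this assay, at which 2 of the 4 values shown sit.

On these data alone, it remains open whether a longer chain such as propyl, or an amine, on this aromatic carbon would give a number clearly apart from compound 4. Compound 1 differs from the others in more than one place, so it cannot settle this question.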